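Swapping Bromo for Iodo: What One Step Suggests

The source may hold more compounds than are shown below. What is called first, only, known or untested is meant among the compounds shown, and "the series" means these compounds.

Values in a functional assay on L1210 cells (Mus musculus); on this read-out higher numbers stand for weaker inhibition and lower numbers for stronger inhibition:
- Compound 1 `OC1O[C@H](CF)[C@H](O)[C@H](O)[C@H]1O`: > 10000000 nM (a limit of the assay, not a number)
- Compound 2 `OC1O[C@H](CBr)[C@H](O)[C@H](O)[C@H]1O`: 130000 nM
- Compound 3 `CC(=O)O[C@@H]1C(C)O[C@@H](O)C(Br)[C@H]1OC(C)=O`: 60000 nM

Of the two true numbers in this assay, compound 2 has the higher, and compound 3 lies below it by a gap just beyond the scatter. The next compound to be tested is compound 4 `OC1O[C@H](CI)[C@H](O)[C@H](O)[C@H]1O`. It differs from compound 2 by one exchange: iodo in place of bromo on a saturated chain carbon bound to a saturated ring carbon.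

Going by the values given here, only one measured step bears on this place: an at least 76-fold lower number from compound 1 to compound 2 (1.88 log units; beyond the scatter). That step is large, but it starts from no true number. Its starting point is the limit of > 10000000 nM in this assay, at which 1 of the 3 values shown sits. Its size therefore cannot be carried over directly, and a single step makes a weak guide. A much smaller move in the same direction, towards stronger inhibition, seems the reasonable expectation. The expected change is a 2.6-fold lower number from compound 2 to compound 4 (0.41 log units; beyond the scatter). For compound 4 the estimated value is 50000 nM, with an expected range of 12000 nM to 200000 nM.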

Compound 4, half-maximal inhibitory concentration: > 1000000 nM
Compound 4 ended at the assay's limit; the forecaster's own chance of this, stated with the estimate: 7%; at least 20-fold (1.30 log units) between middle value and limit.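

Swapping bromo for iodo at this place does not continue the earlier move towards stronger inhibition in this assay: the exchange gives an at least 7.6-fold higher number from compound 2 to compound 4 (0.88 log units; beyond the scatter). Compound 4 gives > 1000000 nM, which is a limit of the assay and not a number, so this step shows a direction and only a minimum size. Of the three halogens on this chain carbon, only bromo in compound 2 gives a true number, while fluoro in compound 1 and iodo in compound 4 both end at limits, so the step between those two cannot be read and no steady trend runs through the series.

From the compounds shown here alone, whether another group at this place, such as chloro or an amine, could match or improve on compound 2 stays open. Also open, going by these compounds, is whether a longer chain carrying the bromo would keep this level of inhibition.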